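The source may hold more compounds than are shown below. What is called first, only, known or untested is meant among the compounds shown, and "the series" means these compounds.

Compound 1 `O=C(Nc1ccc(Oc2ccnc3[nH]ccc23)cc1)c1nn(-c2ccc(Cl)cc2)ccc1=O` in a functional assay on HepG2 cells (Homo sapiens) for cytotoxicity, read by MTT assay, with a stated time of 72 h; a lower number here means a stronger inhibitor, a higher number a weaker inhibitor: 19500 nM
Compound 2 `O=C(Nc1ccc(Oc2ccnc3[nH]ccc23)c(F)c1)c1nn(-c2ccc(Cl)cc2)ccc1=O` in this assay: > 60000 nM
Compound 3 `O=C(Nc1ccc(Oc2ccnc3[nH]ccc23)c(F)c1)c1nn(-c2ccc(Cl)c(C(F)(F)F)c2)ccc1=O` in this assay: 11900 nM

Compound 2 reports only a limit in this assay, not a number. Among the three values shown it sits at the weak end, as given by the limit of > 60000 nM in this assay, at which 1 of the 3 values shown sits. Compound 1 gives 19500 nM and compound 3 gives 11900 nM, both numbers rather than limits.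

Two single-point steps are measured. Fluoro in place of hydrogen on an aromatic carbon gives an at least 3.0-fold higher number from compound 1 to compound 2 (0.48 log units; beyond the scatter). The second step, a trifluoromethyl group entering on an aromatic carbon where hydrogen stood, gives an at least 5.0-fold lower number from compound 2 to compound 3 (0.70 log units; beyond the scatter).

Compound 4 `Cn1ccc2c(Oc3ccc(NC(=O)c4nn(-c5ccc(Cl)cc5)ccc4=O)cc3F)ccnc21` differs from compound 2 by methyl in place of hydrogen on an aromatic nitrogen. Among the measured compounds shown here, neither measured step touches the aromatic nitrogen of the shared core, so no measured step bears directly on this change. The two measured steps only show that small single changes in this series can move the number by at least modest amounts in either direction; they give no direction for this one. The expected step is therefore a number no higher from compound 2 to compound 4 (the limit leaves the size open), none beyond the scatter. For compound 4 the estimate is 60000 nM, within 20000 nM to 150000 nM, and a limit rather than a number is the more likely outcome.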

Compound 4, half-maximal inhibitory concentration: > 60000 nM
Compound 4: no number, only a limit (the forecaster's own chance of this, stated with the estimate: 60%); the middle value sits exactly at the limit.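

Compound 2 and compound 4 both stand only as limits in this assay, so no step can be read for this change: the limit of > 60000 nM in this assay, at which 2 of the 4 values shown sit.

The compounds shown leave open whether methyl in place of hydrogen on an aromatic nitrogen moves the number in either direction.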